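Morpholine to Piperidine on the Sulfonyl of Compound 3

The source may report more compounds than this note shows. Statements on the series, on what has been measured and on what is new or still open speak of the compounds shown alone.

Three compounds have numbers in a functional assay on CHO-K1 cells for antagonist activity at prostaglandin D2 receptor 2 (Homo sapiens), read by scintillation counting and GTPgammaS binding, with stated times of 1 h and 2 h; a higher number here means a weaker inhibitor, a lower number a stronger inhibitor. Compound 1 `COc1c(CC(=O)O)c(C)nn1-c1cccc(NC(=O)[C@H]2C[C@@H]2c2ccccc2)c1` gives 1600 nM, compound 2 `Cc1c(CC(=O)O)c(-c2ccccc2)nn1Cc1ccccc1CS(=O)(=O)c1ccccc1` gives 490 nM and compound 3 `Cc1c(CC(=O)O)c(-c2ccccc2)nn1Cc1ccccc1S(=O)(=O)N1CCOCC1` gives 89 nM. Compound 3 therefore holds the lowest number of the three: compound 2 is the nearest to it, and compound 1 the furthest, both separated from it by more than the scatter. Going by the values given here, the only step between compounds that differ in one place is a 5.5-fold lower number from compound 2 to compound 3 (0.74 log units; beyond the scatter), which concerns the substituent carried by the aromatic carbon of the benzyl group.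

Compound 4 `Cc1c(CC(=O)O)c(-c2ccccc2)nn1Cc1ccccc1S(=O)(=O)N1CCCCC1` is not yet measured. It differs from compound 3 by piperidin-1-yl in place of morpholin-4-yl on a sulfonyl sulfur. Among the compounds with values here, no measured pair shows this exchange; the step from compound 2 to compound 3 touches the same part of the molecule but replaces a different group, so it gives only a rough guide to how much this region tolerates. With nothing measured on the swap itself, the expectation is that the number of compound 4 stays close to that of compound 3, with an expected step of a 1.1-fold lower number from compound 3 to compound 4 (0.05 log units; within the scatter) in this assay. Compound 4 is therefore estimated at 80 nM, with a range from 30 nM to 250 nM.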

Compound 4, half-maximal inhibitory concentration: 66 nM
For compound 4 the middle estimate is 1.2-fold (0.08 log units) above the measured one; low and high end bracket the measured number.
By their numbers in this assay, from the lowest: compounds 4 and 3 (each within the scatter of the next); then compound 2; then compound 1.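

In this assay, going by these compounds alone, the exchange of morpholin-4-yl for piperidin-1-yl on a sulfonyl sulfur gives a 1.3-fold lower number from compound 3 to compound 4 (0.13 log units; within the scatter), the first reading of a change within this ring, and it shows that the ring oxygen of morpholin-4-yl can be lost without a shift beyond the scatter. The wider exchange of (phenylsulfonyl)methyl for (piperidin-1-yl)sulfonyl on the aromatic carbon gives a 7.4-fold lower number from compound 2 to compound 4 (0.87 log units; beyond the scatter), which stands with a 5.5-fold lower number from compound 2 to compound 3 (0.74 log units; beyond the scatter) as a second step beyond the scatter, so the lower number relative to compound 2 is held with either ring on the sulfonyl and does not depend on that oxygen. The data shown offer no measurement that accounts for the two rings giving such similar numbers or for either one's distance from compound 2.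

On these data alone, it remains open whether pyrrolidin-1-yl, piperazin-1-yl or an open-chain dimethylamino group on the sulfonyl sulfur would stay with compound 3 and compound 4 in this assay. Equally open, as far as these compounds go, is whether a carbonyl in place of the sulfonyl, with the piperidin-1-yl kept, would hold the number of compound 4.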